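Dropping the methyl from the aryl ring of compound 2

A few compounds are considered here, and "the series" means these few. Any claim that something is new, unique, unknown or untested is made for them only; others in the source may bear on it.

Measured compounds:
compound 1 `COc1ccc(NC(=O)N/N=C2\O[C@H](CO)[C@@H](O)[C@H](O)[C@H]2NC(C)=O)cc1` — 413 nM
compound 2 `CC(=O)N[C@H]1/C(=N/NC(=O)Nc2ccc(C)cc2)O[C@H](CO)[C@@H](O)[C@@H]1O` — 332 nM

In an assay on isolated protein (Homo sapiens) for inhibition of HEXA/HEXB (Bos taurus), using a Dixon plot (on this read-out lower numbers stand for stronger inhibition and higher numbers for weaker inhibition), compound 1 gives 413 nM and compound 2 gives 332 nM. Compound 2 sits at the low end of these two numbers, but the step of a 1.2-fold lower number from compound 1 to compound 2 (0.09 log units; within the scatter) is within the scatter, so the two are not told apart. Compound 3 `CC(=O)N[C@H]1/C(=N/NC(=O)Nc2ccccc2)O[C@H](CO)[C@@H](O)[C@@H]1O` differs from compound 2 by hydrogen in place of methyl on an aromatic carbon. Among the compounds with values here, the only step that bears on this change, a 1.2-fold lower number from compound 1 to compound 2 (0.09 log units; within the scatter), was itself within the scatter, so for compound 3 a step of a 1.2-fold higher number from compound 2 to compound 3 (0.08 log units; within the scatter) is expected, no larger than the scatter in either direction. Compound 3 is therefore estimated at 400 nM, within 150 nM to 1100 nM.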

Compound 3, inhibition constant: 205 nM
Beside the measured number, compound 3's estimate is 2.0-fold (0.29 log units) above it, within the range that was stated.
By their numbers in this assay, from the lowest: compounds 3, 2 and 1 (each within the scatter of the next).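

In this assay hydrogen in place of methyl stays within the scatter (a 1.6-fold lower number from compound 2 to compound 3 (0.21 log units; within the scatter)), and so does hydrogen in place of methoxy (a 2.0-fold lower number from compound 1 to compound 3 (0.30 log units; within the scatter)). On this aromatic carbon, para to a large group, the bare phenyl of compound 3 therefore cannot be told apart from the substituted rings of compound 1 and compound 2. No evidence is available to explain this result. Going by these compounds, whether an amine, a carboxylic acid or a longer chain at this place would move the number beyond the scatter stays open. So does the effect of any such group elsewhere on the ring.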